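A few compounds are considered here, and "the series" means these few. Any claim that something is new, unique, unknown or untested is made for them only; others in the source may bear on it.

Three compounds were measured in a functional assay on the whole organism (strain albino) for inhibition, with Rattus norvegicus as the target, read by paw edema, with stated times of 1 h and 3 h, at a dose of 100 mg/kg by the oral route; a lower number here means a weaker effect, a higher number a stronger effect of the compound at the dose given:

compound 1, `N#Cc1c(Nc2ccc(Cl)cc2)nc(SCC(=O)Nn2c(COc3ccc(Cl)cc3Cl)nc3ccccc3c2=O)nc1-c1ccccc1`, gives 59.7%;
compound 2, `N#Cc1c(Nc2ccc(O)cc2)nc(SCC(=O)Nn2c(COc3ccc(Cl)cc3Cl)nc3ccccc3c2=O)nc1-c1ccccc1`, gives 59.7%;
compound 3, `N#Cc1c(Nc2ccc(Cl)cc2)nc(SCC(=O)Nn2c(COc3ccc(Cl)cc3Cl)nc3ccccc3c2=O)nc1-c1ccc(O)cc1`, gives 79%.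

Compound 1 and compound 2 share one core and differ in a single place: hydroxy in place of chloro on an aromatic carbon. This change made a step of no change at the digits printed from compound 1 to compound 2 (within the scatter). Compound 3 is built on a second core; how that core differs from the core of compound 1 is counted as hydroxy in place of hydrogen on an aromatic carbon, and this difference made a step of a number 19.3 percentage points higher from compound 1 to compound 3 (beyond the scatter), which leaves compound 3 with the highest number of the three.

Compound 4, `N#Cc1c(Nc2ccc(O)cc2)nc(SCC(=O)Nn2c(COc3ccc(Cl)cc3Cl)nc3ccccc3c2=O)nc1-c1ccc(O)cc1`, has not been measured. It stands to compound 3 as compound 2 stands to compound 1: hydroxy in place of chloro on an aromatic carbon. The place is described in the same words for both pairs, so this is the same change, now on the core of compound 3. Among the measured compounds shown here, the only guide to its effect is the step of no change at the digits printed from compound 1 to compound 2 (within the scatter) on the first core, and on that step rests the expectation that the step from compound 3 to compound 4 will be about as small, a number 1 percentage points lower from compound 3 to compound 4 (within the scatter). The number for compound 4 in this assay is therefore estimated at 78%, with a plausible range from 65% to 89%, the width reflecting that the change is seen only once and on a different core.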

Compound 4, a percentage reported as inhibition, in the whole organism at one dose (the size of the read-out at that dose, not a potency): 86.8%
Compound 4: middle estimate off by 8.8 percentage points, on the low side; the range from low to high includes it.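

In this assay, the same exchange of chloro for hydroxy, read as (4-chlorophenyl)amino to (4-hydroxyphenyl)amino, gave a number 7.8 percentage points higher from compound 3 to compound 4 (within the scatter), and set beside the step on the first core it shows no difference that can be told from scatter: the same change on two cores in this assay, no change at the digits printed (within the scatter) from compound 1 to compound 2 and a number 7.8 percentage points higher (within the scatter) from compound 3 to compound 4, 7.8 percentage points apart, within the scatter of two such steps. The second change, hydroxy in place of hydrogen on an aromatic carbon, gave a number 27.1 percentage points higher from compound 2 to compound 4 (beyond the scatter), and it too agrees with its earlier counterpart, so it carried over in size as well as in direction: the same change on two cores in this assay, a number 19.3 percentage points higher (beyond the scatter) from compound 1 to compound 3 and a number 27.1 percentage points higher (beyond the scatter) from compound 2 to compound 4, 7.8 percentage points apart, within the scatter of two such steps. Together the four compounds show that each change behaved alike on the two cores tested, but each comparison rests on only two pairs read at a single dose, so this does not show that the changes would carry over to any other core, nor does it give a potency for any compound.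

The compounds shown hold only chloro or hydroxy on the (phenyl)amino ring, so what a methoxy group, an amine or a carboxylic acid would do in that place remains open. Also open, going by these compounds, is whether the hydroxy gain seen on the other phenyl ring would survive a longer chain in the linker that joins the two halves of these molecules.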